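The compounds below may be only part of what the source reports. "The series", "measured", "known", "first", "only" and "open" are said of these compounds alone.

Compound 1 `CC(C)(C)Nc1nc2sc(-c3ccccc3)cc2c(=O)[nH]1` and compound 2 `CC(C)(C)Nc1nc2sc(-c3ccc(F)cc3)cc2c(=O)[nH]1` share the core with compound 3 `CC(C)(C)Nc1nc2nc(-c3ccccc3)sc2c(=O)[nH]1`. In a toxicity assay on HepG2 cells (Homo sapiens) for cytotoxicity, read by MTT assay, with a stated time of 72 h (a lower number here means that less compound is tolerated, a higher number that more compound is tolerated), compound 1 gives > 12500 nM, which is a limit of the assay and not a number. Compound 2 gives > 25000 nM, also a limit. Compound 3 gives > 25000 nM, again only a limit. For the measured compounds named here, the one measured step, a step that the two limits leave unreadable from compound 1 to compound 2, is not readable; it joins two values that are limits, as the limit of > 12500 nM in this assay, at which 1 of the 3 values shown sits, and the limit of > 25000 nM in this assay, at which 2 of the 3 values shown sit, show. Compound 3 therefore stands only at the upper bound of what was tested. Compound 4 `Cc1ccc(-c2nc3nc(NC(C)(C)C)[nH]c(=O)c3s2)cc1` carries the change (methyl in place of hydrogen on an aromatic carbon), methyl in place of hydrogen on an aromatic carbon, para to a large group. Going by the values given here, no measured step bears on this change. No step beyond the scatter is expected for a step that the limit leaves unreadable from compound 3 to compound 4. Compound 4 is estimated at 30000 nM, within 12500 nM to 100000 nM, most likely reported as a limit.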

Compound 4, half-maximal cytotoxic concentration: > 5000 nM
Compound 4 gave a limit, no number (the forecaster's own chance of this, stated with the estimate: 85%); the middle value does not contradict the limit.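

No step can be read from compound 3 to compound 4: both values are limits of the assay, not numbers. The compounds shown leave open whether phenyl to 4-methylphenyl shifts the half-maximal cytotoxic concentration in this assay at all.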